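Halogen swap at the shared core: fluoro, bromo, then chloro

The source may hold more compounds than are shown below. What is called first, only, known or untested is meant among the compounds shown, and "the series" means these compounds.

Measured so far:
compound 1, `O=c1[nH]c(=O)n([C@H]2C[C@@H]3O[PH](O)(O)OC[C@H]3O2)cc1F` — 7.4 ug/mL
compound 2, `O=c1[nH]c(=O)n([C@H]2C[C@@H]3O[PH](O)(O)OC[C@H]3O2)cc1Br` — > 1000 ug/mL

Compound 1, `O=c1[nH]c(=O)n([C@H]2C[C@@H]3O[PH](O)(O)OC[C@H]3O2)cc1F`, gives 7.4 ug/mL in a functional assay on L1210 cells (Mus musculus) for antiproliferative activity; a higher number here means a weaker inhibitor, a lower number a stronger inhibitor. Compound 2, `O=c1[nH]c(=O)n([C@H]2C[C@@H]3O[PH](O)(O)OC[C@H]3O2)cc1Br`, reaches only the limit of the assay, > 1000 ug/mL, so for compound 2 there is no number, only a bound; (the limit of > 1000 ug/mL in this assay, at which 1 of the 2 values shown sits). For the measured compounds named here, the one measured step, an at least 130-fold higher number from compound 1 to compound 2 (2.13 log units; beyond the scatter), thus stands as a lower bound on the real change.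

Compound 3, `O=c1[nH]c(=O)n([C@H]2C[C@@H]3O[PH](O)(O)OC[C@H]3O2)cc1Cl`, is not yet measured. It differs from compound 2 in one place: chloro in place of bromo on an aromatic carbon. Going by the values given here, the step that bears on it is the exchange of fluoro for bromo between compound 1 and compound 2, which was large; chloro sits between the two halogens in size, but no measured step shows where a chloro compound falls, and the bound on compound 2 leaves the span open.

Compound 3 is therefore expected to fall somewhere between the two measured points, with a wide range, at about 250 ug/mL, between 30 ug/mL and 1000 ug/mL. The expected step is an at least 4.0-fold lower number from compound 2 to compound 3 (0.60 log units; beyond the scatter), reckoned from the bound of compound 2.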

Compound 3, concentration for 50% inhibition: > 1000 ug/mL
Compound 3: a limit, no number; the forecaster's own chance of this, stated with the estimate: 35%; middle value at least 4.0-fold (0.60 log units) away from the limit.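

In this assay compound 3 gives > 1000 ug/mL, which is a limit of the assay and not a number, and so the chloro compound sits with the bromo compound, not with the fluoro compound: the limit of > 1000 ug/mL in this assay, at which 2 of the 3 values shown sit.

The loss seen earlier is therefore not tied to bromo alone, for chloro in place of fluoro on the same aromatic carbon brings an at least 130-fold higher number from compound 1 to compound 3 (2.13 log units; beyond the scatter), again a lower bound on the real change, and among the three halogens shown only fluoro gives a readable value. The step between the bromo and chloro compounds cannot be read, and no order of the two follows from these data.

Going by these compounds, how far the true values of compound 2 and compound 3 lie beyond the limit remains unknown. Also open, on these data alone, is whether a hydrogen, a methyl group or a trifluoromethyl group on this aromatic carbon would give a readable value like that of compound 1 or would sit at the same limit.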